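A few compounds are considered here, and "the series" means these few. Any claim that something is new, unique, unknown or untested is made for them only; others in the source may bear on it.

Measured so far in an ADME assay on L6 cells (Rattus norvegicus) for cytotoxicity, read by resazurin assay, with a stated time of 72 h; on this read-out higher numbers stand for weaker inhibition and lower numbers for stronger inhibition:
- Compound 1 `OC(c1ccc(Cl)cc1)(c1cccnc1)c1ccccc1F`: > 100000 nM (a limit of the assay, not a number)
- Compound 2 `OC(c1ccc(Cl)cc1)(c1cccnc1)c1ccc(C(F)(F)F)cc1F`: 57400 nM

Within the data shown here, compound 2, at 57400 nM, holds the only true number in this assay, so there is no second number to rank it against. Compound 3 `N#Cc1ccc(C(O)(c2ccc(Cl)cc2)c2cccnc2)c(F)c1` has cyano in place of trifluoromethyl on an aromatic carbon, para to a large group: cyano in place of trifluoromethyl on an aromatic carbon.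

Among the measured compounds shown here, only one measured step bears on this change, and it concerns the same aromatic carbon: an at least 1.7-fold lower number from compound 1 to compound 2 (0.24 log units; that floor lies within the scatter). There, trifluoromethyl took the place of hydrogen, and the smallest size that step could have lies within the scatter. From the compounds shown here alone, for compound 1 the step starts from the limit of > 100000 nM in this assay, at which 1 of the 2 values shown sits, so its true size is unknown. This gives little reason to expect a clear shift in either direction, and compound 3 could also return only a limit. The expected change is a 1.1-fold higher number from compound 2 to compound 3 (0.05 log units; within the scatter), which is not expected to go beyond the scatter. In this assay, compound 3 is estimated at 65000 nM, with an expected range from 30000 nM to 100000 nM.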

Compound 3, half-maximal inhibitory concentration: > 100000 nM
Compound 3: a limit, no number (the forecaster's own chance of this, stated with the estimate: 35%); middle value at least 1.5-fold (0.18 log units) from the limit.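

At this aromatic carbon, para to a large group, this assay gives an at least 1.7-fold higher number from compound 2 to compound 3 (0.24 log units; that floor lies within the scatter). Compound 2 is therefore the only one of the three with a true number, while hydrogen and cyano at this carbon both end at the limit, yet that floor alone does not show that cyano and trifluoromethyl truly differ. The step between the two compounds that carry hydrogen and cyano at this carbon, compound 1 and compound 3, cannot be read: the limit of > 100000 nM in this assay, at which 2 of the 3 values shown sit.

From the compounds shown here alone, the true sizes of the steps remain open, and so does whether trifluoromethyl is unusual at this carbon or merely sits close to the limit. Also open, going by these compounds, is what another group at this carbon, such as an amine, a carboxylic acid or a longer chain, would do in this assay.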